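A few compounds are considered here, and "the series" means these few. Any claim that something is new, unique, unknown or untested is made for them only; others in the source may bear on it.

In an assay (strain Wistar) for inhibition of Hormone-sensitive lipase (Rattus norvegicus), read by spectrophotometry (a higher number here means a weaker inhibitor, a lower number a stronger inhibitor), compound 3 `CCCCc1c(C)n(C(=O)N2CCC(C)CC2)oc1=O` gives 1 nM, the lowest of the two numbers recorded in this assay. Compound 1 `Cc1c(C2CCOCC2)c(=O)on1C(=O)N1CCCCC1` gives 71 nM in this assay, a value that lies beyond the scatter above that of compound 3. For compound 2 `Cc1c(C(C)C)c(=O)on1C(=O)N(C)CCC#N` this assay returned only a limit, > 1000 nM, and no number is known for it (the limit of > 1000 nM in this assay, at which 1 of the 3 values shown sits). For the measured compounds named here, no two of these measured compounds differ from each other in a single place, so no measured step is available to lean on.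

Compound 4 `Cc1c(C2CCCCC2)c(=O)on1C(=O)N1CCC(C)CC1` has not yet been tested in this assay. It differs from compound 3 in one place: cyclohexyl in place of butyl on an aromatic carbon. Going by the values given here, nothing among the measured compounds shows what this exchange does, since compound 1 carries a different group and a different amide, and compound 2 gave only a limit. The step of a 3.0-fold higher number from compound 3 to compound 4 (0.48 log units; beyond the scatter) is expected to be small, if anything toward a weaker inhibitor, and most likely within the scatter. Compound 4 is therefore expected to give about 3 nM in this assay, with a range from 0.5 nM to 20 nM.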

Compound 4, half-maximal inhibitory concentration: 4 nM
Beside the measured number, compound 4's estimate is 1.3-fold (0.12 log units) below it; the measured number falls inside the stated range.
By their numbers in this assay, from the lowest: compound 3; then compound 4; then compound 1. At a limit, above all of these: compound 2.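

In this assay this position now has a measured step of its own, cyclohexyl in place of butyl on an aromatic carbon, and it reads a 4.0-fold higher number from compound 3 to compound 4 (0.60 log units; beyond the scatter). The step lies beyond the scatter, so the two groups are not interchangeable here, but it is modest: with a ring in place of the open chain, compound 4 still gives 4 nM. For the compounds shown here, compound 3 and compound 4 differ nowhere else, whereas compound 1 and compound 2 each differ from both of them in more than one place, so this is the first reading that belongs to this position alone.

The data shown give no cause for this step. From the compounds shown here alone, it remains open how a shorter chain such as ethyl, a longer chain such as hexyl, or a phenyl group would read at this position, and whether cyclohexyl in place of butyl would give a step of similar size with the amide of compound 1.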